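A few compounds are considered here, and "the series" means these few. Any claim that something is new, unique, unknown or untested is made for them only; others in the source may bear on it.

Measured in a functional assay on KM12 cells (Homo sapiens) for cytotoxicity, read by sulforhodamine B assay, with a stated time of 48 h, tested at 0.1 uM; on this read-out higher numbers stand for a weaker effect at the one concentration tested and lower numbers for a stronger effect:

compound 1, `COc1cc(-c2cc(/C=C/C(=O)c3ccc(Cl)c(Cl)c3)[nH]n2)cc(OC)c1OC`, gives 93%.
compound 2, `COc1ccc(-c2cc(/C=C/C(=O)c3cc(OC)c(OC)c(OC)c3)[nH]n2)cc1OC`, gives 92%.
compound 3, `COc1ccc(-c2cc(/C=C/C(=O)c3ccc(N)cc3)[nH]n2)cc1`, gives 97%.

Among the compounds with values here, all three numbers sit high on this read-out, so none of the measured compounds shows more than a weak effect at the single concentration tested. Compound 1 stands second highest of the three; the value of compound 2 lies close to it and the gap falls within the scatter, and the value of compound 3, the furthest of the three from compound 1, also lies within the scatter. On these numbers no ordering among compounds 1, 2 and 3 can be claimed.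

Compound 4, `COc1ccc(C(=O)/C=C/c2cc(-c3cc(OC)c(OC)c(OC)c3)n[nH]2)cc1OC`, is the next member to be measured. Compared with compound 1 the change is 3,4-dimethoxyphenyl in place of 3,4-dichlorophenyl on a carbonyl carbon. Within the data shown here, no measured pair shows this change in isolation, so the step has to be judged from the series as a whole, and the series so far offers no case where any substitution moves the number beyond the scatter. The step from compound 1 to compound 4 is therefore expected to be small, no change at the digits printed from compound 1 to compound 4 (within the scatter), in no particular direction beyond the scatter. Compound 4 is estimated at 93%, with a range from 82% to 103%.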

Compound 4, a percentage reported as activity, at one concentration (the size of the read-out at that concentration, not a potency): 92%
For compound 4 the middle estimate is 1 percentage points above the measured one, and the stated range covers the measured number.
By their numbers in this assay, from the lowest: compounds 2, 4, 1 and 3 (each within the scatter of the next).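

Within the data shown here, on a carbonyl carbon, 3,4-dimethoxyphenyl in place of 3,4-dichlorophenyl gives the first pair that differs in one place, and in this assay the step reads a number 1 percentage points lower from compound 1 to compound 4 (within the scatter). At this position, then, an exchange of two chlorine atoms for two methoxy groups, which adds hydrogen-bond acceptors to the group, leaves the read-out inside the scatter at the one concentration tested, on the core of compound 1. Nothing at hand offers an account of this flat result.

Still open, going by these compounds, is whether a phenyl carrying a carboxylic acid or a nitrile on the same carbonyl carbon would move the number beyond the scatter. Also open, on these data alone, is whether this exchange would read the same at a higher concentration, where the effect might no longer sit so close to the top of the read-out.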